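Replacing the anilino headgroup on a macrocyclic amine quinazoline

The source may hold more compounds than are shown below. What is called first, only, known or untested is meant among the compounds shown, and "the series" means these compounds.

The series holds two measured compounds that share one core and differ only in the size of a saturated ring at the end of a propoxy chain. Compound 1 `C#Cc1cccc(Nc2ncnc3cc(OC)c(OCCCN4CCNCCNCCNCC4)cc23)c1` gives 1110 nM in a functional assay on A-431 cells (Homo sapiens) for antiproliferative activity, read by MTT assay, with a stated time of 72 h; on this read-out lower numbers stand for stronger inhibition and higher numbers for weaker inhibition. Compound 2 `C#Cc1cccc(Nc2ncnc3cc(OC)c(OCCCN4CCNCCNCC4)cc23)c1` gives 2230 nM in this assay. Within the data shown here, the only step between them, a 2.0-fold higher number from compound 1 to compound 2 (0.30 log units; within the scatter), stays within the scatter, so compound 2 has the highest of the two numbers without being separable from compound 1.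

Compound 3 `CCc1cc(Br)ccc1Nc1ncnc2cc(OC)c(OCCCN3CCNCCNCC3)cc12` keeps the nine-membered ring of compound 2 and changes the other end of the molecule: 4-bromo-2-ethylphenyl in place of 3-ethynylphenyl on a nitrogen on an aromatic ring. Among the measured compounds shown here, no measured step touches the aryl group on the amino nitrogen; the one step known, a 2.0-fold higher number from compound 1 to compound 2 (0.30 log units; within the scatter), concerns the macrocycle and says nothing about the change from (3-ethynylphenyl)amino to (4-bromo-2-ethylphenyl)amino. Without a comparable pair, the expectation for this assay rests on compound 2 alone, and the step of a 1.1-fold higher number from compound 2 to compound 3 (0.05 log units; within the scatter) is expected to remain within the scatter, in no preferred direction. Compound 3 is therefore estimated at 2500 nM, with a range from 700 nM to 9000 nM.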

Compound 3, half-maximal inhibitory concentration: 18800 nM
For compound 3 the middle estimate is 7.5-fold (0.88 log units) below the measured one; the measured number lies above the stated range.
By their numbers in this assay, from the lowest: compounds 1 and 2 (each within the scatter of the next); then compound 3.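

Among these compounds, with the nine-membered ring held fixed, the aryl group on the amino nitrogen, which no earlier step had touched, proves able to move the number in this assay: 4-bromo-2-ethylphenyl in place of 3-ethynylphenyl gives an 8.4-fold higher number from compound 2 to compound 3 (0.93 log units; beyond the scatter) and thus weaker inhibition. Of the two changes now on record, only this one stands beyond the scatter, since the change of ring size between compound 1 and compound 2 does not. Nothing available bears on why this exchange raises the number.

The step exchanges one whole aryl group for another, so it cannot separate the departure of the ethynyl group from the arrival of the bromine or the ethyl group, and a 4-bromophenyl or 2-ethylphenyl group on the same nitrogen would be needed to divide the effect. Going by these compounds, it also remains open whether the 4-bromo-2-ethylphenyl group would have a comparable effect on the larger ring of compound 1, or on a piperazine or morpholine at the end of the propoxy chain.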